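The source may hold more compounds than are shown below. What is called first, only, known or untested is meant among the compounds shown, and "the series" means these compounds.

In a physicochemical assay for solubility, read by nephelometry, at pH 7.4 (a lower number here means a less soluble compound, a higher number a more soluble compound), compound 2 `COc1cccc(NC(=O)c2nnn(Cc3ccc(C#N)cc3)c2N)c1` reads 216000 nM, the higher of the two actual numbers in this small set. Compound 3 `COc1cccc(NC(=O)c2nnn(C(C)c3ccc(C(C)(C)C)cc3)c2N)c1` gives the other number, 20000 nM. Compound 1 `COc1cccc(NC(=O)c2nnn(CC3CCN(C(C)=O)CC3)c2N)c1` shows > 250000 nM, which is a limit of the assay and not a number.

Compound 4 `COc1cccc(NC(=O)c2nnn(Cc3cc(C)on3)c2N)c1` has 5-methyl-1,2-oxazol-3-yl in place of 4-cyanophenyl on a saturated chain carbon bound to an aromatic nitrogen. For the measured compounds named here, the one measured step at this place is an at least 1.1-fold lower number from compound 1 to compound 2 (0.06 log units; that floor lies within the scatter), and it gives only a floor. On that evidence, no step beyond the scatter is expected in this assay. The estimated step is a 1.1-fold higher number from compound 2 to compound 4 (0.03 log units; within the scatter). Compound 4 is estimated at 230000 nM, with an expected range of 120000 nM to 250000 nM.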

Compound 4, solubility: 174000 nM
For compound 4 the middle estimate is 1.3-fold (0.12 log units) above the measured one; the range from low to high includes it.
By their numbers in this assay, from the lowest: compound 3; then compounds 4 and 2 (each within the scatter of the next). At a limit, above all of these: compound 1.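

In this assay, 5-methyl-1,2-oxazol-3-yl in place of 4-cyanophenyl at this place gives a 1.2-fold lower number from compound 2 to compound 4 (0.09 log units; within the scatter), so a five-membered aromatic ring with 2 hetero atoms and a six-membered aromatic ring of carbon only read alike here. Against 1-acetylpiperidin-4-yl, the step is an at least 1.4-fold lower number from compound 1 to compound 4 (0.15 log units; that floor lies within the scatter). Compound 1 stands at a limit, so this step is only a floor: the limit of > 250000 nM in this assay, at which 1 of the 4 values shown sits.

Going by these compounds, how a carboxylic acid or an amine on this saturated chain carbon would read remains open. The shown compounds also do not separate the extra methyl on the chain carbon of compound 3 from its tert-butyl group.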